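Trimming the Ring on the Carbonyl: Cyclohexyl to Cyclobutyl

The source may hold more compounds than are shown below. What is called first, only, known or untested is meant among the compounds shown, and "the series" means these compounds.

Compound 3 `O=C(C1CCCCC1)N1CCN(c2nc(=O)c3cc(C(F)(F)F)cc([N+](=O)[O-])c3s2)CC1` was tested in a physicochemical assay for solubility, read by HPLC (on this read-out lower numbers stand for lower solubility and higher numbers for higher solubility), and gives 3.24 ug/mL, the second highest of three numbers. In this assay compound 1 `O=C(CC1CCCCC1)N1CCN(c2nc(=O)c3cc(C(F)(F)F)cc([N+](=O)[O-])c3s2)CC1` gives 0.12 ug/mL, and compound 2 `CSCC(=O)N1CCN(c2nc(=O)c3cc(C(F)(F)F)cc([N+](=O)[O-])c3s2)CC1` gives 15.2 ug/mL. Compound 4 `O=C(C1CCC1)N1CCN(c2nc(=O)c3cc(C(F)(F)F)cc([N+](=O)[O-])c3s2)CC1` has not yet been measured; it differs from compound 3 by cyclobutyl in place of cyclohexyl on a carbonyl carbon. Among the measured compounds shown here, two measured steps bear on this. The step of a 27-fold higher number from compound 1 to compound 3 (1.43 log units; beyond the scatter) shows that a smaller group on the carbonyl carbon came with a much higher number, and the step of a 4.7-fold lower number from compound 2 to compound 3 (0.67 log units; beyond the scatter) shows the direction reversing when the group on that carbon grew. For compound 4 a modest rise is therefore expected, a 3.7-fold higher number from compound 3 to compound 4 (0.57 log units; beyond the scatter). Compound 4 is estimated at 12 ug/mL, with a range from 4 ug/mL to 40 ug/mL.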

Compound 4, solubility: 39.3 ug/mL
The estimate for compound 4 lay 3.3-fold (0.52 log units) below the measured number; low and high end bracket the measured number.
By their numbers in this assay, from the lowest: compound 1; then compound 3; then compound 2; then compound 4.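

In this assay, cyclobutyl in place of cyclohexyl on a carbonyl carbon gives a 12-fold higher number from compound 3 to compound 4 (1.08 log units; beyond the scatter), so changing only the size of this carbon ring, with no hydrogen-bond donor or acceptor entering, moves the number a long way. The all-carbon cyclobutyl also outdoes (methylsulfanyl)methyl, with a 2.6-fold higher number from compound 2 to compound 4 (0.41 log units; beyond the scatter), so a sulfur atom is not needed for the highest number here, and the span at this position widens to a 330-fold higher number from compound 1 to compound 4 (2.52 log units; beyond the scatter). No measurement shown explains these steps.

Still open, as far as these compounds go, is how a smaller cyclopropyl ring, an amine or a carboxylic acid on this carbonyl carbon would compare with cyclobutyl.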